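A few compounds are considered here, and "the series" means these few. Any claim that something is new, unique, unknown or untested is made for them only; others in the source may bear on it.

Measured compounds:
compound 1 `Cc1nn(-c2ncnc3nc[nH]c23)c2c1C(C(=O)NCc1ccccc1)CC(=O)N2` — 2930 nM
compound 2 `Cc1nn(-c2ncnc3nc[nH]c23)c2c1C(OCCn1nccc1C)CC(=O)N2` — 1620 nM

In a functional assay on HEK293 cells for agonist activity at G-protein coupled receptor 39 (Homo sapiens), read by scintillation proximity assay and inositol phosphate accumulation, with a stated time of 75 min (on this read-out lower numbers stand for an effect already at smaller amounts and higher numbers for an effect only at larger amounts of compound), compound 2 gives the lowest of the two numbers; the nearest is compound 1, and the step of a 1.8-fold lower number from compound 1 to compound 2 (0.26 log units; within the scatter) stays within the scatter, so the two cannot be ranked against each other.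

Compound 3 `Cc1nn(-c2ncnc3nc[nH]c23)c2c1C(OCc1ccc(F)cc1)CC(=O)N2` differs from compound 2 by 4-fluorophenyl in place of (5-methyl-1H-pyrazol-1-yl)methyl on a saturated chain carbon bound to an oxygen on a saturated carbon. Among the measured compounds shown here, no measured step touches this position in the same way. For the measured compounds named here, the only step known, a 1.8-fold lower number from compound 1 to compound 2 (0.26 log units; within the scatter), exchanged groups of similar size, one carrying a six-membered carbon-only aromatic ring and one a five-membered aromatic ring with two hetero atoms, without moving beyond the scatter. The present change brings a six-membered carbon-only aromatic ring back while the oxygen on the saturated carbon stays. The expected step of a 1.2-fold higher number from compound 2 to compound 3 (0.09 log units; within the scatter) is therefore small, with no direction beyond the scatter. Compound 3 is estimated at 2000 nM, within a range of 700 nM to 6000 nM.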

Compound 3, half-maximal effective concentration: 126 nM
Beside the measured number, compound 3's estimate is 16-fold (1.20 log units) above it; measured number below the stated range.
By their numbers in this assay, from the lowest: compound 3; then compounds 2 and 1 (each within the scatter of the next).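

In this assay, the group on the saturated chain carbon bound to an oxygen on a saturated carbon is far from interchangeable: 4-fluorophenyl in place of (5-methyl-1H-pyrazol-1-yl)methyl gives a 13-fold lower number from compound 2 to compound 3 (1.11 log units; beyond the scatter). The saturated ring carbon also shows a step beyond the scatter, which compounds 1 and 2 did not show, with (4-fluorobenzyl)oxy in place of benzylcarbamoyl giving a 23-fold lower number from compound 1 to compound 3 (1.37 log units; beyond the scatter). Nothing at hand accounts for the size of these steps.

Going by these compounds, whether the lower number follows the fluorine or the six-membered aromatic ring of carbon only stays open, and an unsubstituted benzyloxy group, or chlorine or methoxy in place of the fluorine, would separate the two. Also open, on these data alone, is how an amine or a carboxylic acid on this chain would read.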